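The source may hold more compounds than are shown below. What is called first, only, known or untested is meant among the compounds shown, and "the series" means these compounds.

Compound 1 `CCn1c(SCC(=O)Nc2ccc(/C(C)=N/O)cc2)nnc1-c1ccc(OC)c(OC)c1` and compound 2 `COc1ccc(-c2nnc(SCC(=O)Nc3ccc(/C(C)=N/O)cc3)n2-c2ccccc2)cc1OC` share one core, while compound 3 `CCn1c(SCC(=O)Nc2ccc(C(C)=O)cc2)nnc1-c1ccccc1` is built on another; how the two cores differ is not broken down here. In a functional assay on the whole organism (strain albino) for inhibition, with Rattus norvegicus as the target, read by paw edema, with stated times of 30 min and 5 h, at a dose of 0.28 mmol/kg by the oral route (a higher number here means more inhibition at the dose given (going by the name of the read-out), a lower number less inhibition), compound 1 gives 73%, compound 2 gives 76%, and compound 3 gives 66%. The change from compound 1 to compound 2 is phenyl in place of ethyl on an aromatic nitrogen, and it made a number 3 percentage points higher from compound 1 to compound 2 (within the scatter). Compound 4 `CC(=O)c1ccc(NC(=O)CSc2nnc(-c3ccccc3)n2-c2ccccc2)cc1` has not yet been measured; it is made from compound 3 by the same kind of change, (phenyl in place of ethyl on an aromatic nitrogen). The surroundings of the place differ in one respect: in compound 1 the place is next to the ring atom that bears a 3,4-dimethoxyphenyl group, whereas in compound 3 it is next to the ring atom that bears a phenyl group. For the measured compounds named here, because the one measured example a number 3 percentage points higher from compound 1 to compound 2 (within the scatter) stayed within the scatter, a step of similar size is expected, namely a number 3 percentage points higher from compound 3 to compound 4 (within the scatter) in this assay. Compound 4 is thus expected to give 69% in this assay, most likely between 58% and 80%.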

Compound 4, a percentage reported as inhibition, in the whole organism at one dose (the size of the read-out at that dose, not a potency): 63%
Compound 4: middle estimate off by 6 percentage points, on the high side; low and high end bracket the measured number.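

Putting phenyl in place of ethyl on the aromatic nitrogen gave a number 3 percentage points lower from compound 3 to compound 4 (within the scatter) in this assay. Set beside the earlier example, the two steps show no real difference: the same change on two cores in this assay, a number 3 percentage points higher (within the scatter) from compound 1 to compound 2 and a number 3 percentage points lower (within the scatter) from compound 3 to compound 4, 6 percentage points apart, within the scatter of two such steps. This shows that, on these two cores, the change behaves alike within the limits of the measurement, but it does not show that the change raises or lowers the read-out on either core, and two pairs say nothing about how it would behave on a third core.

The compounds shown leave open whether a different group on that ring nitrogen, such as a benzyl group, a longer chain like butyl or a chain ending in an amine, would give a step beyond the scatter. They also leave open whether the change would look the same at another dose, as each compound is read at a single dose.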